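Reversed amide on the indole core of compound 1

The compounds below may be only part of what the source reports. "The series", "measured", "known", "first", "only" and "open" are said of these compounds alone.

Compound 1 `COc1cc(C(=O)NS(=O)(=O)c2ccccc2C)ccc1Cn1cc(C)c2ccc(C(=O)NCC3CCCC3)cc21` is one of two measured members of this series; in an assay on isolated protein for binding affinity to cysteinyl leukotriene receptor 1 (Cavia porcellus) (a lower number here means a less potent compound, a higher number a more potent compound, by a factor of ten per unit of this negative logarithm), compound 1 gives 8.9. Compound 2 `COc1cc(C(=O)NS(=O)(=O)c2ccccc2C)ccc1Cc1cn(C)c2ccc(NC(=O)CC3CCCC3)cc12` gives 9.7 in this assay, so compound 1 stands lowest of the two numbers, with compound 2 a step higher that lies beyond the scatter. Among the compounds with values here, no single-change step between measured compounds is available.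

Compound 3 `COc1cc(C(=O)NS(=O)(=O)c2ccccc2C)ccc1Cn1cc(C)c2ccc(NC(=O)CC3CCCC3)cc21` is unmeasured. It shares all atoms with compound 1, joined differently: ((cyclopentylmethyl)carbonyl)amino in place of (cyclopentylmethyl)carbamoyl on an aromatic carbon. Within the data shown here, no measured pair isolates this change, so its size rests on the broader picture only. The step from compound 1 to compound 3 in this assay is expected to be upward, a number 0.50 log units higher from compound 1 to compound 3 (beyond the scatter), though a result within the scatter is also possible. The upward direction for compound 3 is expected because compound 2, which carries the entering ((cyclopentylmethyl)carbonyl)amino group, gives 9.7. For compound 3 in this assay the estimate is 9.4, with a range from 8.7 to 10.1.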

Compound 3, negative logarithm of the antagonist equilibrium constant: 9.3
Estimate against measurement, compound 3: 0.10 log units above, within the range that was stated.
By their numbers in this assay, from the lowest: compound 1; then compound 3; then compound 2.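

Placing ((cyclopentylmethyl)carbonyl)amino where (cyclopentylmethyl)carbamoyl stood on this aromatic carbon is the first single-place change in the series. In this assay it gives a number 0.40 log units higher from compound 1 to compound 3 (beyond the scatter) with the rest of the structure unchanged. The two groups have the same heavy atoms and the same counts of donors and acceptors, so the step belongs to the way the amide is joined to the aromatic carbon rather than to any change in composition, and this position is therefore sensitive to that joining, though only modestly so far. No measurement at hand accounts for the step.

Going by these compounds, whether the same exchange gives a step of similar size with a cyclohexyl ring or a longer chain in place of the cyclopentyl ring remains open. Also open, on these data alone, is what a urea or a carbamate on this same aromatic carbon would give against the two amides, and whether an N-methyl group on the amide nitrogen would keep the higher number seen with the ((cyclopentylmethyl)carbonyl)amino group.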